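The source may report more compounds than this note shows. Statements on the series, on what has been measured and on what is new or still open speak of the compounds shown alone.

Compound 1, `O=C(OC[C@H]1CN(c2ccc(-n3cc(-c4ccccn4)cn3)c(F)c2)C(=O)O1)c1ccccc1`, is the starting point. In a physicochemical assay for solubility, read by HPLC, with a stated time of 24 h (on this read-out lower numbers stand for lower solubility and higher numbers for higher solubility), compound 1 gives <= 65400 nM, which is a limit of the assay rather than a number, so compound 1 stands at or beneath that limit. Its measured partner compound 2, `CCC(=O)NC[C@H]1CN(c2ccc(-n3cc(-c4ccccn4)cn3)c(F)c2)C(=O)O1`, gives 147000 nM in this assay. For the measured compounds named here, the single measured step runs an at least 2.2-fold higher number from compound 1 to compound 2 (0.35 log units; beyond the scatter), and the only evidence on it is the limit of <= 65400 nM in this assay, at which 1 of the 2 values shown sits. Compound 3, `CONC(=O)[C@H]1CN(c2ccc(-n3cc(-c4ccccn4)cn3)c(F)c2)C(=O)O1`, differs from compound 1 as follows: methoxycarbamoyl in place of (benzoyloxy)methyl on a saturated ring carbon. Like the measured step, this change removes the six-membered aromatic ring of carbon only while a hydrogen-bond donor enters, so a higher number beyond the scatter is expected, of a size comparable to or somewhat larger than the step from compound 1 to compound 2. Compound 3 is therefore expected to reach about 160000 nM, with a range from 65000 nM to 400000 nM. The estimated step is an at least 2.4-fold higher number from compound 1 to compound 3 (0.38 log units; beyond the scatter).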

Compound 3, solubility: 78100 nM
Compound 3: middle estimate off by 2.0-fold (0.31 log units), on the high side, within the range that was stated.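

In this assay, methoxycarbamoyl in place of (propanoylamino)methyl on this saturated ring carbon gives a 1.9-fold lower number from compound 2 to compound 3 (0.27 log units; within the scatter), so the two groups cannot be told apart at this position. Methoxycarbamoyl in place of (benzoyloxy)methyl gives an at least 1.1-fold higher number from compound 1 to compound 3 (0.07 log units; that floor lies within the scatter), so unlike an at least 2.2-fold higher number from compound 1 to compound 2 (0.35 log units; beyond the scatter), this change does not show a rise beyond the scatter, even though it also removes the six-membered aromatic ring of carbon only and brings in a hydrogen-bond donor. Compound 1 carries a limit of the assay rather than a number, and the true size of both steps from it stays unknown: the limit of <= 65400 nM in this assay, at which 1 of the 3 values shown sits.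

The compounds shown leave open how far compound 1 really lies from the other two. They also leave open whether an amine, a carboxylic acid or a longer chain on this ring carbon would shift the number beyond the scatter.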